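This account rests on a few compounds, and the source may have more. Where it says the series, first, only, none or still open, it means among the compounds named here.

Measured in a functional assay on A549 cells (Homo sapiens) for cytotoxicity, read by MTT assay, with a stated time of 48 h; a lower number here means a stronger inhibitor, a higher number a weaker inhibitor:
- compound 1 `CC1(C)CCC[C@]2(C)[C@@H](CC[C@@](C)(O)/C=C/c3cccc([N+](=O)[O-])c3)[C@](C)(O)CC[C@@H]12`: 3400 nM
- compound 2 `CC1(C)CCC[C@]2(C)[C@@H](CC[C@@](C)(O)/C=C/c3cncc4ccccc34)[C@](C)(O)CC[C@@H]12`: 45700 nM
- compound 3 `CC1(C)CCC[C@]2(C)[C@@H](CC[C@@](C)(O)/C=C/c3ccc(Cl)nc3)[C@](C)(O)CC[C@@H]12`: 3280 nM

Compound 3 shares the low end of these numbers with compound 1, as there is a 1.0-fold lower number from compound 1 to compound 3 (0.02 log units; within the scatter). Compound 2 lies well apart, with a 14-fold lower number from compound 2 to compound 3 (1.14 log units; beyond the scatter).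

Compound 4 `CC1(C)CCC[C@]2(C)[C@@H](CC[C@@](C)(O)/C=C/c3ccc(C(=O)O)cc3)[C@](C)(O)CC[C@@H]12` has not yet been measured. It carries 4-carboxyphenyl in place of 6-chloropyridin-3-yl on a double-bonded chain carbon bound to a double-bonded chain carbon.

Within the data shown here, two measured steps bear on this change. Exchanging 3-nitrophenyl for 6-chloropyridin-3-yl made no difference beyond the scatter, whereas isoquinolin-4-yl gave a 13-fold higher number from compound 1 to compound 2 (1.13 log units; beyond the scatter). Compound 4 keeps one six-membered aromatic ring, so a step as large as that one seems unlikely. Among the measured compounds shown here, still, no measured compound carries 4-carboxyphenyl, so the data offer no direct guide and the range must stay wide.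

In this assay the expected change is a modest one towards a higher number, a 2.4-fold higher number from compound 3 to compound 4 (0.39 log units; beyond the scatter). The estimated value for compound 4 is 8000 nM, with an expected range of 2500 nM to 40000 nM.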

Compound 4, half-maximal inhibitory concentration: 44300 nM
The estimate for compound 4 lay 5.5-fold (0.74 log units) below the measured number; the whole stated range lies below it.
By their numbers in this assay, from the lowest: compounds 3 and 1 (each within the scatter of the next); then compounds 4 and 2 (each within the scatter of the next).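

In this assay, keeping one six-membered aromatic ring at this place on the chain does not keep the number low: the change to 4-carboxyphenyl gives a 14-fold higher number from compound 3 to compound 4 (1.13 log units; beyond the scatter) and, measured against the nitro compound, a 13-fold higher number from compound 1 to compound 4 (1.11 log units; beyond the scatter) as well. The step is as large as the one seen earlier with isoquinolin-4-yl, and the two groups now sit together, with a 1.0-fold lower number from compound 2 to compound 4 (0.01 log units; within the scatter) within the scatter, so the presence of a single aromatic ring does not by itself sort these compounds. No measurement here explains why the carboxy group behaves this way.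

The compounds shown leave open whether the carboxy group itself accounts for the step or whether the whole 4-substituted ring does. A methyl ester or a primary amide in its place on the same phenyl ring would help separate the two.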